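The source may report more compounds than this note shows. Statements on the series, on what has been measured and on what is new or still open speak of the compounds shown alone.

Compound 1 `CC(=O)N(Cc1ccccc1)Cc1ncnc2c1ncn2[C@@H]1O[C@H](CO)[C@@H](O)[C@H]1O`: in a functional assay on Huh-7 cells (Homo sapiens) for cytotoxicity, read by MTT assay, with a stated time of 3 days (on this read-out lower numbers stand for higher toxicity in this test and higher numbers for lower toxicity in this test), compound 1 gives only the limit > 100000 nM.
Compound 2 `CC(=O)N(Cc1ncnc2c1ncn2[C@@H]1O[C@H](CO)[C@@H](O)[C@H]1O)C1CCCCC1`: in this assay compound 2 gives only the limit > 100000 nM.
Compound 3 `COCc1ncnc2c1ncn2[C@@H]1O[C@H](CO)[C@@H](O)[C@H]1O`: in this assay compound 3 gives only the limit > 100000 nM.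

Compound 3 therefore stands at the same limit as the other two measured compounds, and no order among the three can be read. Compound 4 `OC[C@H]1O[C@@H](n2cnc3c(Cn4ccc5ccccc54)ncnc32)[C@H](O)[C@@H]1O` differs from compound 3 by 1H-indol-1-yl in place of methoxy on a saturated chain carbon bound to an aromatic carbon. Within the data shown here, the only measured step, a step that the two limits leave unreadable from compound 1 to compound 2, is unreadable, and the limit of > 100000 nM in this assay, at which 3 of the 3 values shown sit, covers every value shown, so neither a direction nor a size can be drawn for this assay from the measured compounds. On that basis compound 4 is expected to sit at the limit as well, with an estimated value of 100000 nM between 30000 nM and 300000 nM. The step of a number no higher from compound 3 to compound 4 (the limit leaves the size open) is thus expected to lie within the scatter.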

Compound 4, half-maximal cytotoxic concentration: > 250000 nM
Compound 4 gave a limit, no number (the forecaster's own chance of this, stated with the estimate: 80%); middle value at least 2.5-fold (0.39 log units) from the limit.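

Among these compounds, compound 3 and compound 4 both give only limits in this assay, so no step between them can be read. The compounds shown leave open at what concentration any of them becomes toxic to these cells.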